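Chloro for methyl on the indole ring of compound 2

The source may report more compounds than this note shows. Statements on the series, on what has been measured and on what is new or still open speak of the compounds shown alone.

Measured compounds:
compound 1 `COC(=O)[C@@]1(C)CCC=C2[C@@H]1CC[C@@H](C)[C@]2(C)Cc1c(C)[nH]c2ccc(Cl)cc12` with 18000 nM
compound 2 `COC(=O)[C@@]1(C)CC[C@@H]2C3=C1CC[C@@H](C)[C@]3(C)Cc1c2[nH]c2c(C)cccc12` with 22000 nM

Of the compounds shown here, two have been tested in a functional assay on WiDr cells (Homo sapiens) for inhibition, read by sulforhodamine B assay, with a stated time of 48 h; a lower number here means a stronger inhibitor of growth, a higher number a weaker inhibitor of growth. Compound 1 gives 18000 nM in this assay, and compound 2 gives 22000 nM. Compound 2 holds the higher of the two numbers, but its nearest neighbour, compound 1, sits within the usual scatter of it, so the two cannot be told apart on these measurements alone. The two structures differ in more than one place, so no single change can be read from that pair.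

Compound 3 `COC(=O)[C@@]1(C)CC[C@@H]2C3=C1CC[C@@H](C)[C@]3(C)Cc1c2[nH]c2c(Cl)cccc12` has not yet been measured. It differs from compound 2 in one place: chloro in place of methyl on an aromatic carbon. Going by the values given here, no measured pair shows what such a swap does on this core, so the expectation rests on little. With compound 2 at 22000 nM and compound 1, which also carries a chloro group, at 18000 nM, the author expects the step from compound 2 to compound 3 to be small, a 1.2-fold lower number from compound 2 to compound 3 (0.09 log units; within the scatter), likely not beyond the scatter in either direction. Compound 3 is therefore estimated at 18000 nM in this assay, within a range from 7000 nM to 45000 nM.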

Compound 3, concentration for 50% growth inhibition: 21000 nM
Estimate against measurement, compound 3: 1.2-fold (0.07 log units) below, within the range that was stated.
By their numbers in this assay, from the lowest: compounds 1, 3 and 2 (each within the scatter of the next).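

In this assay the swap of chloro for methyl gives a 1.0-fold lower number from compound 2 to compound 3 (0.02 log units; within the scatter), and this is the only comparison among the compounds shown that isolates a single change on one core. It shows that, on this aromatic carbon, ortho to a fused ring and meta to a fused ring, the two groups cannot be told apart in this read-out, whereas compound 1 and compound 2 differ in more than one place and could say nothing about either group alone. No measurement shown here bears on why the number stays within the scatter for this exchange of one heavy atom for another.

As far as these compounds go, whether the result reaches beyond these two groups remains open, since only methyl and chloro have been compared here, and a hydrogen, an amine, a carboxylic acid or a longer chain on the same aromatic carbon could give a different answer. From the compounds shown here alone, it is also open whether the same swap would behave alike on another core, such as the core of compound 1.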